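Swapping the Core Ring on the Carbonyl Carbon

The compounds below may be only part of what the source reports. "The series", "measured", "known", "first", "only" and "open" are said of these compounds alone.

Compound 1 `O=C(CCCCCCc1ccccc1)c1ncno1` was tested in an assay for inhibition of Fatty-acid amide hydrolase 1 (Rattus norvegicus), at pH 9.0 (on this read-out lower numbers stand for stronger inhibition and higher numbers for weaker inhibition), where compound 1 gives 1 nM. Among the three measured compounds, compound 1 holds the second highest number. Compound 2 `O=C(CCCCCCc1ccccc1)c1nc(-c2ccccn2)no1` gives 0.34 nM, and the step of a 2.9-fold lower number from compound 1 to compound 2 (0.47 log units; beyond the scatter) lies beyond the scatter. Compound 3 `O=C(CCCCCCc1ccccc1)c1nc(-c2cccs2)no1` gives 1.6 nM, and the step of a 1.6-fold higher number from compound 1 to compound 3 (0.20 log units; within the scatter) stays within the scatter, while the step of a 4.7-fold higher number from compound 2 to compound 3 (0.67 log units; beyond the scatter) exceeds it.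

Compound 4 `O=C(CCCCCCc1ccccc1)c1nnn[nH]1` differs from compound 1 in the ring attached to the carbonyl: 1H-tetrazol-5-yl in place of 1,2,4-oxadiazol-5-yl on a carbonyl carbon. Going by the values given here, none of the measured steps bears on this, since each of them replaces a hydrogen on an aromatic carbon and leaves the shared core untouched. With no guidance from the data, the expected step is a modest weakening, a 20-fold higher number from compound 1 to compound 4 (1.30 log units; beyond the scatter). Compound 4 is therefore estimated at 20 nM, with a range from 2 nM to 200 nM.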

Compound 4, inhibition constant: > 1000 nM
Compound 4 was reported as a limit; the forecaster's own chance of this, stated with the estimate: 5%; middle value at least 50-fold (1.69 log units) from the limit.
By their numbers in this assay, from the lowest: compound 2; then compounds 1 and 3 (each within the scatter of the next). At a limit, above all of these: compound 4.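

Earlier steps only replaced a hydrogen on an aromatic carbon and kept the shared core, so they said nothing about the ring on the carbonyl carbon itself. Changing that ring matters far more, with 1H-tetrazol-5-yl in place of 1,2,4-oxadiazol-5-yl giving an at least 1000-fold higher number from compound 1 to compound 4 (3.00 log units; beyond the scatter). The result for compound 4 is a limit and not a number: the limit of > 1000 nM in this assay, at which 1 of the 4 values shown sits.

The entering ring has a hydrogen-bond donor and the leaving ring has none, but these compounds cannot show whether that difference is what counts. Also open, as far as these compounds go, is what a methyl group in place of the hydrogen on the 1H-tetrazol-5-yl ring would do.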